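The source may report more compounds than this note shows. Statements on the series, on what has been measured and on what is new or still open speak of the compounds shown alone.

Values in an ADME assay on HCT-116 cells (Homo sapiens) for cytotoxicity, read by CellTiter-Glo, with a stated time of 72 h; a lower number here means a stronger inhibitor, a higher number a weaker inhibitor:
- Compound 1 `Cc1noc(C)c1S(=O)(=O)N1CCC(N2CCC(C)CC2)CC1`: > 10000 nM
- Compound 2 `CC1CCN(C2CCN(S(=O)(=O)c3ccc(Cl)nc3)CC2)CC1`: > 10000 nM
- Compound 3 `COc1cccc(S(=O)(=O)N2CCC(N3CCC(C)CC3)CC2)c1`: > 5000 nM

All three entries are limits and not numbers. Compound 3 gives > 5000 nM, which is a limit. It stands at the limit of > 5000 nM in this assay, at which 1 of the 3 values shown sits. The other two compounds stand at the limit of > 10000 nM in this assay, at which 2 of the 3 values shown sit.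

Compound 4 `CC1CCN(C2CCN(S(=O)(=O)c3ccc(F)cc3F)CC2)CC1` is still to be measured in this assay. It keeps the core of compound 3 and carries 2,4-difluorophenyl in place of 3-methoxyphenyl on a sulfonyl sulfur.

For the measured compounds named here, three measured steps bear on this change, as each exchanges one group for another at that same sulfonyl sulfur. They are a step that the two limits leave unreadable from compound 1 to compound 2, a step that the two limits leave unreadable from compound 1 to compound 3 and a step that the two limits leave unreadable from compound 2 to compound 3. None of them has a size that can be read, so they offer no direction and no magnitude to carry over. All three compounds that vary at this place end in limits, and none goes against that pattern.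

The expected change, a step that the limit leaves unreadable from compound 3 to compound 4, is therefore none beyond the scatter, in either direction. For compound 4 the estimate is 8000 nM, with an expected range from 4000 nM to 20000 nM. A report as a limit is the likeliest outcome in this assay.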

Compound 4, half-maximal inhibitory concentration: > 5000 nM
Compound 4: no number, only a limit (the forecaster's own chance of this, stated with the estimate: 85%); the middle value lies beyond the limit too.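

In this assay compound 4 gives > 5000 nM, which is a limit and not a number. Its steps from compound 1, compound 2 and compound 3 therefore cannot be read. The compounds shown leave open where any of the four actual values lies, and whether exchanging the group on the sulfonyl sulfur changes the value at all.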